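A few compounds are considered here, and "the series" means these few. Any claim that something is new, unique, unknown or untested is made for them only; others in the source may bear on it.

Compound 1 `C=C1C(=O)[C@@]23C(=O)OC[C@]4(C(=O)CCC(C)(C)[C@H]4C=O)[C@@H]2CC[C@@H]1[C@H]3OC(=O)c1ccc(C(F)(F)F)cc1`: 3990 nM
Compound 2 `C=C1C(=O)[C@@]23C(=O)OC[C@]4(C(=O)CCC(C)(C)[C@H]4C=O)[C@@H]2CC[C@@H]1[C@H]3OC(=O)c1ccccc1F`: 3950 nM

In a functional assay on Bel-7402 cells (Homo sapiens) for cytotoxicity, read by MTT assay, with a stated time of 72 h (on this read-out lower numbers stand for stronger inhibition and higher numbers for weaker inhibition), compound 2 gives 3950 nM, level with compound 1 at 3990 nM; the two numbers cannot be told apart. Compound 3 `C=C1C(=O)[C@@]23C(=O)OC[C@]4(C(=O)CCC(C)(C)[C@H]4C=O)[C@@H]2CC[C@@H]1[C@H]3OC(=O)c1ccc(Cl)cc1` has not yet been measured. It keeps the shared core and alters a single group: 4-chlorophenyl in place of 2-fluorophenyl on a carbonyl carbon. Put simply, it has 4-chlorophenyl in place of 2-fluorophenyl on a carbonyl carbon.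

For the measured compounds named here, only one measured step bears on this change. Going to 2-fluorophenyl in place of 4-(trifluoromethyl)phenyl on that same carbonyl carbon gave a 1.0-fold lower number from compound 1 to compound 2 (0.00 log units; within the scatter). So one exchange of the group at this place left the number within the scatter. This is thin evidence, since a single step between two compounds cannot show how a chlorine-bearing ring will behave. It still offers no reason to expect a shift, so no step beyond the scatter is expected here. The expected step is a 1.0-fold lower number from compound 2 to compound 3 (0.01 log units; within the scatter). For compound 3 the estimated value is 3900 nM, with an expected range of 1800 nM to 8500 nM.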

Compound 3, half-maximal inhibitory concentration: 3840 nM
Beside the measured number, compound 3's estimate is 1.0-fold (0.01 log units) above it; low and high end bracket the measured number.
By their numbers in this assay, from the lowest: compounds 3, 2 and 1 (each within the scatter of the next).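

With compound 3 in hand, the ester's aromatic ring has now been exchanged further, and in this assay the number again does not move: the swap of 2-fluorophenyl for 4-chlorophenyl gives (a 1.0-fold lower number from compound 2 to compound 3 (0.01 log units; within the scatter)), and the chloro for trifluoromethyl exchange on the aromatic carbon gives (a 1.0-fold lower number from compound 1 to compound 3 (0.02 log units; within the scatter)). Across these three compounds, then, the identity of the halogen-bearing ring on this carbonyl carbon makes no readable difference, whether the ring carries fluoro, chloro or trifluoromethyl, and no compound shown goes against this. Nothing available explains why these rings behave alike in the cell assay.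

All three rings carry fluorine or chlorine, so this flat result says nothing yet about a plain phenyl ring, or about a ring bearing an amine or a carboxylic acid. It also leaves open whether a longer chain in place of the ring on this carbonyl carbon would shift the number, and so how much this position can tolerate before cytotoxicity changes.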